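This account rests on a few compounds, and the source may have more. Where it says the series, first, only, none or still open, it means among the compounds named here.

Measured compounds in a physicochemical assay for inhibition, read by colorimetric assay, tested at 1 mg/mL; on this read-out lower numbers stand for less inhibition and higher numbers for more inhibition at the one concentration tested (going by the name of the read-out):
- compound 1 `COc1ccc(/C=C2\CCC3C2=NN(c2nc(-c4ccc(Cl)cc4)cs2)C3c2ccc(OC)cc2)cc1` gives 27.5%
- compound 2 `CCN1C/C(=C\c2ccc(OC)cc2)C2=NN(C(N)=S)C(c3ccc(OC)cc3)C2C1` gives 88.2%
- compound 3 `COc1ccc(/C=C2\CCCc3c2nc(N)c(C#N)c3-c2ccc(OC)c(OC)c2)cc1OC` gives 9.73%

Compound 2 stands highest of the three numbers in this assay. Compound 1 is nearest to it and lies beyond the scatter below it; compound 3 is furthest and also lies beyond the scatter below it. Among the compounds with values here, the three compounds differ in more than one place, so no single step between them can be read off.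

The next compound to be measured is compound 4 `CCN1C/C(=C\c2ccc(OC)cc2)C2=NN(c3nc(-c4ccc(Cl)cc4)cs3)C(c3ccc(OC)cc3)C2C1`. It differs from compound 2 in one place: a group of 12 heavy atoms (9 carbon, 1 nitrogen, 1 sulfur, 1 chlorine; one five-membered aromatic ring with 2 hetero atoms, one six-membered aromatic ring of carbon only) in place of a group of 3 heavy atoms (1 carbon, 1 nitrogen, 1 sulfur; no ring), on an amine nitrogen in a ring The same 4-(4-chlorophenyl)-1,3-thiazol-2-yl group stands on the core of compound 1, which carries a different fused system and no ring amine, so it is only an indirect pointer.

Compound 4 is expected to give 45% in this assay, within a range of 20% to 75%. The step of a number 43.2 percentage points lower from compound 2 to compound 4 (beyond the scatter) is thus estimated as a decrease beyond the scatter, because compound 1 with the entering group gives 27.5% on its own core. The range is wide, since compound 2 is the only direct anchor.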

Compound 4, a percentage reported as inhibition, at one concentration (the size of the read-out at that concentration, not a potency): 82.6%
The estimate for compound 4 lay 37.6 percentage points below the measured number; measured number above the stated range.
By their numbers in this assay, from the lowest: compound 3; then compound 1; then compounds 4 and 2 (each within the scatter of the next).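

On the shared core, placing 4-(4-chlorophenyl)-1,3-thiazol-2-yl on this amine nitrogen in place of the group of 3 heavy atoms gives, in this assay, a number 5.6 percentage points lower from compound 2 to compound 4 (within the scatter). This read-out therefore does not separate the two groups, although the entering group has two aromatic rings and no hydrogen-bond donor, whereas the leaving group has no ring and one donor. No accompanying measurement bears on why the two groups read alike.

Still open, on these data alone, is whether the position accepts other groups, such as acetyl or an unsubstituted phenyl, and whether the chlorine on the entering group contributes at all. With only one concentration shown, compound 2 and compound 4 may also separate at lower concentrations.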